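Replacing the oxanylmethyl amine in a chemokine receptor agonist series

The compounds below may be only part of what the source reports. "The series", "measured", "known", "first", "only" and "open" are said of these compounds alone.

Of the compounds shown here, three built on one shared core have been tested in a functional assay on cells for agonist activity at C-X-C chemokine receptor type 4 (Homo sapiens), read by fluorescence and calcium flux, with a stated time of 90 s; a lower number here means that less compound is needed, a higher number that more compound is needed for the effect. Compound 1 `c1ccc2c(c1)CN[C@@H](CN(CCCCNCC1CCCCC1)[C@H]1CCCc3cccnc31)C2` gives only a limit of the assay, > 30000 nM. Compound 2 `NCc1ccccc1CN(C[C@H]1Cc2ccccc2CN1)[C@H]1CCCc2cccnc21` likewise gives only a limit, > 30000 nM. Compound 3 `C(=C/CN(C[C@H]1Cc2ccccc2CN1)[C@H]1CCCc2cccnc21)\CNCC1CCOCC1` also sits at a limit, > 30000 nM. All three values are one and the same limit, so none of the steps between them can be read: the step that the two limits leave unreadable from compound 1 to compound 2, the step that the two limits leave unreadable from compound 1 to compound 3 and the step that the two limits leave unreadable from compound 2 to compound 3 have no readable size, because of the limit of > 30000 nM in this assay, at which 3 of the 3 values shown sit.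

Compound 4 `CC1(C)CCC(NC/C=C/CN(C[C@H]2Cc3ccccc3CN2)[C@H]2CCCc3cccnc32)CC1` differs from compound 3 by one change: 4,4-dimethylcyclohexyl in place of (oxan-4-yl)methyl on an amine nitrogen. Among the compounds with values here, no measured step bears directly on this change, since every step between the measured compounds is hidden by the same limit. What the numbers do show is that three varied groups at this part of the molecule all leave the compound without measurable effect in this assay. Compound 4 is therefore expected to behave the same way, with an estimated step of a number no higher from compound 3 to compound 4 (the limit leaves the size open). Compound 4 is estimated at 30000 nM, in a range from 10000 nM to 100000 nM, most likely reported again only as a limit.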

Compound 4, half-maximal effective concentration: > 30000 nM
Compound 4: no number, only a limit (the forecaster's own chance of this, stated with the estimate: 85%); the middle value lies on the limit itself.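

Compound 4 gives > 30000 nM, which is a limit and not a number. The change from compound 3 to compound 4 therefore has no readable size, because the values all stop at the same point: the limit of > 30000 nM in this assay, at which 4 of the 4 values shown sit.

The compounds shown leave open whether any group on this amine nitrogen would give a measurable value in this assay.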